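Swapping a Ring for an Amide Arm on Shared Core

A few compounds are considered here, and "the series" means these few. Any claim that something is new, unique, unknown or untested is made for them only; others in the source may bear on it.

Measured so far:
compound 1, `CCOC(=O)C1=Cc2ccccc2OC1(OCc1cn(CC(=O)Nc2ccc(OC)cc2)nn1)C(F)(F)F`, gives 28100 nM in a functional assay on MCF7 cells (Homo sapiens) for inhibition, read by MTT assay, with a stated time of 24 h; a higher number here means a weaker inhibitor, a lower number a stronger inhibitor
compound 2, `CCOC(=O)C1=Cc2ccccc2OC1(OCc1cn(CC(=O)Nc2ccccc2F)nn1)C(F)(F)F`, gives 42100 nM
compound 3, `CCOC(=O)C1=Cc2ccccc2OC1(OCc1cn(-c2ccc(F)c(Cl)c2)nn1)C(F)(F)F`, gives 25300 nM

All three share one core and differ only in the group on the aromatic nitrogen of a five-membered aromatic ring with three nitrogen atoms. Compound 3 holds the lowest of the three numbers, yet the steps to it, a 1.1-fold lower number from compound 1 to compound 3 (0.05 log units; within the scatter) and a 1.7-fold lower number from compound 2 to compound 3 (0.22 log units; within the scatter), both lie within the scatter, and so does a 1.5-fold higher number from compound 1 to compound 2 (0.18 log units; within the scatter); none of the three can be called stronger or weaker than another.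

Compound 4, `CCOC(=O)C1=Cc2ccccc2OC1(OCc1cn(CC(=O)Nc2cccc(F)c2)nn1)C(F)(F)F`, is not yet measured. Its change from compound 3 is ((3-fluorophenyl)carbamoyl)methyl in place of 3-chloro-4-fluorophenyl on an aromatic nitrogen. This returns to the kind of group carried by compounds 1 and 2, only with a 3-fluorophenyl on the amide-type nitrogen. Among the measured compounds shown here, the steps that bear on it, a 1.1-fold lower number from compound 1 to compound 3 (0.05 log units; within the scatter) and a 1.7-fold lower number from compound 2 to compound 3 (0.22 log units; within the scatter), were both small, and a 1.5-fold higher number from compound 1 to compound 2 (0.18 log units; within the scatter) shows that changing the ring on that nitrogen also moved little. For compound 4 the expected step is therefore a 1.3-fold higher number from compound 3 to compound 4 (0.12 log units; within the scatter), nothing beyond the scatter. Compound 4 is estimated at 33000 nM, with a range from 15000 nM to 70000 nM.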

Compound 4, half-maximal inhibitory concentration: > 150000 nM
Compound 4: no number, only a limit; the forecaster's own chance of this, stated with the estimate: 10%; middle value at least 4.5-fold (0.65 log units) from the limit.
By their numbers in this assay, from the lowest: compounds 3, 1 and 2 (each within the scatter of the next). At a limit, above all of these: compound 4.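

In this assay, compound 4 has only a limit of the assay, not a number: the limit of > 150000 nM in this assay, at which 1 of the 4 values shown sits. The ring on the amide-type nitrogen can matter after all: 3-fluorophenyl in place of 2-fluorophenyl gives an at least 3.5-fold higher number from compound 2 to compound 4 (0.55 log units; beyond the scatter), and 3-fluorophenyl in place of 4-methoxyphenyl gives an at least 5.3-fold higher number from compound 1 to compound 4 (0.72 log units; beyond the scatter). Replacing 3-chloro-4-fluorophenyl on the aromatic nitrogen with ((3-fluorophenyl)carbamoyl)methyl gives an at least 5.9-fold higher number from compound 3 to compound 4 (0.77 log units; beyond the scatter), yet compounds 1 and 2 carry the same kind of arm and stay within the scatter of compound 3, so the arm alone does not account for this step.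

Going by these compounds, with only a limit for compound 4, the full size of these steps stays unknown. Also open, on these data alone, is how an amine or a carboxylic acid on that phenyl ring, or a longer chain between the triazole nitrogen and the amide, would read in this assay.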